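A Second Bromo Group on a Cytotoxic Compound

This account rests on a few compounds, and the source may have more. Where it says the series, first, only, none or still open, it means among the compounds named here.

In a functional assay on P388 cells (Mus musculus) for cytotoxicity (a higher number here means a weaker inhibitor, a lower number a stronger inhibitor), compound 1 `Brc1ccc2c(-c3nc(-c4c[nH]c5ccccc45)c[nH]3)c[nH]c2c1` gives 4500 nM as its reading. Compound 2 `Brc1ccc2c(-c3c[nH]c(-c4c[nH]c5ccccc45)n3)c[nH]c2c1` gives 4500 nM as well, so it stands level with compound 1, and the two cannot be separated on these numbers.

Compound 3 `Brc1ccc2c(-c3c[nH]c(-c4c[nH]c5cc(Br)ccc45)n3)c[nH]c2c1` is compound 2 with a single change bromo in place of hydrogen on an aromatic carbon and in plain words this is a bromo in place of hydrogen on an aromatic carbon. That carbon belongs to a six-membered aromatic ring of carbon only, part of a fused or bridged system of two rings.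

Among the compounds with values here, no measured pair of compounds shows what this change does, so a forecast has little to rest on. Within the data shown here, the only anchor is compound 2 at 4500 nM and so the expected step in this assay is small, with no firm direction and probably nothing beyond the usual scatter. The estimated step runs a 1.1-fold higher number from compound 2 to compound 3 (0.05 log units; within the scatter) and the uncertainty around it is wide. For compound 3 the estimated value is 5000 nM with an expected range of 1500 nM to 18000 nM in this measurement.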

Compound 3, half-maximal inhibitory concentration: 4500 nM
Compound 3: middle estimate off by 1.1-fold (0.05 log units), on the high side; the measured number falls inside the stated range.
By their numbers in this assay, from the lowest: compounds 1, 2 and 3 (each within the scatter of the next).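

In this assay, within the data shown here, putting a bromo in place of hydrogen on this aromatic carbon gives no change at the digits printed from compound 2 to compound 3 (within the scatter) and this is the first sign of how the position responds, since the earlier compounds carried only hydrogen there. Set against compound 1 the result is the same, with no change at the digits printed from compound 1 to compound 3 (within the scatter) so a second bromo group on the shared core leaves the cytotoxic reading unmoved in both comparisons. No measurement at hand explains why this swap leaves the number in place.

A single substituent at a single carbon cannot show whether this position tolerates nearly any group or only a bromo, and the three compounds together say nothing about the other open carbons of the core. An amine, a carboxylic acid or a longer chain such as butyl on the same carbon would test that question more sharply, and only such a comparison could show whether this carbon matters for the reading at all.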